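Cyano in Place of Hydrogen on the Anilide of Compound 3

This account rests on a few compounds, and the source may have more. Where it says the series, first, only, none or still open, it means among the compounds named here.

Three compounds have been measured in an in vitro assay on Sf21 cells for inhibition of high affinity 3',5'-cyclic-AMP phosphodiesterase 7A (Homo sapiens), read by scintillation proximity assay, with a stated time of 30 min; on this read-out lower numbers stand for stronger inhibition and higher numbers for weaker inhibition:
compound 1 `CCN(CC)c1ccc(NC(=O)c2cn(Cc3c(F)cccc3F)c3ccc(=O)[nH]c3c2=O)cc1`, giving 46 nM;
compound 2 `CC(=O)Nc1ccc(NC(=O)c2cn(Cc3c(F)cccc3F)c3ccc(=O)[nH]c3c2=O)cc1`, giving 24 nM;
compound 3 `O=C(Nc1ccccc1)c1cn(Cc2c(F)cccc2F)c2ccc(=O)[nH]c2c1=O`, giving 94 nM.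

Compound 3 stands highest of the three numbers. The two steps that reach it both remove a group from the aromatic carbon in question: a 2.0-fold higher number from compound 1 to compound 3 (0.31 log units; beyond the scatter) and a 3.9-fold higher number from compound 2 to compound 3 (0.59 log units; beyond the scatter), a modest rise in each case. Compound 1 and compound 2 lie within the scatter of each other, as a 1.9-fold lower number from compound 1 to compound 2 (0.28 log units; within the scatter) shows.

Compound 4 `N#Cc1ccc(NC(=O)c2cn(Cc3c(F)cccc3F)c3ccc(=O)[nH]c3c2=O)cc1` has not yet been measured. It differs from compound 3 by cyano in place of hydrogen on an aromatic carbon. Both measured steps bear on this change, since each shows that a group at this position, in place of hydrogen, gives a lower number than compound 3 itself. The cyano group is smaller than either group tested, so a modest lowering is expected rather than a large one. Compound 4 is therefore estimated at 45 nM, with a range from 18 nM to 110 nM, which would amount to an expected 2.1-fold lower number from compound 3 to compound 4 (0.32 log units; beyond the scatter).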

Compound 4, half-maximal inhibitory concentration: 96 nM
Estimate against measurement, compound 4: 2.1-fold (0.33 log units) below; the measured number falls inside the stated range.
By their numbers in this assay, from the lowest: compounds 2 and 1 (each within the scatter of the next); then compounds 3 and 4 (each within the scatter of the next).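

In this assay, the step of a 1.0-fold higher number from compound 3 to compound 4 (0.01 log units; within the scatter) shows that a group on this aromatic carbon, para to a large group, does not by its presence alone lower the number, as the acetamido and diethylamino groups had suggested. What enters here therefore matters: replacing those groups with cyano gives a 4.0-fold higher number from compound 2 to compound 4 (0.60 log units; beyond the scatter) and a 2.1-fold higher number from compound 1 to compound 4 (0.32 log units; beyond the scatter), both modest steps. The data offer no measurement that accounts for the difference between cyano and the other two groups.

From the compounds shown here alone, only hydrogen, cyano, acetamido and diethylamino have been compared here, so it remains open how a primary amine, a methoxy group or a carboxylic acid at this place would read. Going by these compounds, whether cyano would read the same on another carbon of this ring also remains open.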